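The source may report more compounds than this note shows. Statements on the series, on what has been measured and on what is new or still open speak of the compounds shown alone.

Series notes. Compound 1 `CCOc1nc2cccc(C(=O)NCc3ccco3)c2n1Cc1ccc(-c2ccccc2-c2nnn[nH]2)cc1` and compound 2 `CCOc1nc2cccc(C(=O)NCc3ccccc3)c2n1Cc1ccc(-c2ccccc2-c2nnn[nH]2)cc1` share one core and differ only at the group on the saturated chain carbon bound to the amide-type nitrogen. For the measured compounds named here, in an assay on isolated protein for inhibition of NEDD8-activating enzyme E1 regulatory subunit (Homo sapiens), read by Western blot, with stated times of 10 min and 30 min, tested at 25 uM (a lower number here means less inhibition, a higher number more inhibition at the concentration tested (going by the name of the read-out)), compound 1 gives 37.5%, and in this assay compound 2 gives 48.9%, the higher of the two numbers; the single measured step, a number 11.4 percentage points higher from compound 1 to compound 2 (beyond the scatter), is beyond the scatter. Compound 3 `CCOc1nc2cccc(C(=O)NOCc3ccccc3)c2n1Cc1ccc(-c2ccccc2-c2nnn[nH]2)cc1` is not yet measured. Its difference from compound 2 is benzyloxy in place of benzyl on an amide-type nitrogen. The measured step exchanges the ring on the saturated chain carbon and does not bear on benzyloxy in place of benzyl on the amide-type nitrogen, so it gives no direction for this change. Going by the values given here, with no bearing step, the expected movement in this assay for compound 3 is none beyond the scatter, with a wide range kept. Compound 3 is therefore estimated at 45%, between 25% and 65%, which corresponds to a number 3.9 percentage points lower from compound 2 to compound 3 (within the scatter).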

Compound 3, a percentage reported as inhibition, at one concentration (the size of the read-out at that concentration, not a potency): 39.8%
The estimate for compound 3 lay 5.2 percentage points above the measured number; the range from low to high includes it.
By their numbers in this assay, from the lowest: compounds 1, 3 and 2 (each within the scatter of the next, the first and the last beyond it).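

In this assay, the step for benzyloxy in place of benzyl on the amide-type nitrogen is a number 9.1 percentage points lower from compound 2 to compound 3 (within the scatter) and so gives no separation between these two groups at this position. The step for benzyloxy in place of (furan-2-yl)methyl is a number 2.3 percentage points higher from compound 1 to compound 3 (within the scatter) and likewise gives no separation, which leaves compound 3 within the scatter of both compound 1 and compound 2, even though those two lie beyond the scatter of each other. Nothing at hand bears on the reason for these numbers.

The compounds shown leave open whether a longer chain such as phenethyl, or a bare hydroxy group, on the amide-type nitrogen would move the number beyond the scatter. All three readings come from one tested concentration, so they leave potency open as well.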